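The compounds below may be only part of what the source reports. "The series", "measured", "known", "first", "only" and "open" are said of these compounds alone.

Working notes on the aryl sulfone series.

Three compounds share one core and differ only in the aryl ring on the sulfonyl sulfur. Compound 1 `CC1CCN(c2c(S(=O)(=O)c3cccc(Cl)c3)cnc3cc(Cl)ccc23)CC1` gives 92% in an assay on isolated protein for displacement of a labelled ligand from metabotropic glutamate receptor 5 (Homo sapiens), with a stated time of 60 min, tested at 1 uM; on this read-out higher numbers stand for more inhibition at the one concentration tested (going by the name of the read-out) and lower numbers for less inhibition. Compound 2 `CC1CCN(c2c(S(=O)(=O)c3cc(F)cc(F)c3)cnc3cc(Cl)ccc23)CC1` gives 94% in this assay, and compound 3 `CC1CCN(c2c(S(=O)(=O)c3ccc(F)cc3)cnc3cc(Cl)ccc23)CC1` gives 91%. The steps between them are small: a number 2 percentage points higher from compound 1 to compound 2 (within the scatter), a number 1 percentage points lower from compound 1 to compound 3 (within the scatter) and a number 3 percentage points lower from compound 2 to compound 3 (within the scatter). Compound 3 is therefore not separated from compound 1 or compound 2 on these numbers; the three sit together at the high end of the read-out.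

Compound 4 `COc1ccc(S(=O)(=O)c2cnc3cc(Cl)ccc3c2N2CCC(C)CC2)cc1OC` has not yet been measured. It differs from compound 3 in one place: 3,4-dimethoxyphenyl in place of 4-fluorophenyl on a sulfonyl sulfur. All three measured steps bear on this change, since each also exchanges the aryl ring on the sulfonyl sulfur, and none of them moved the read-out beyond the scatter. For the measured compounds named here, the entering group is larger and carries two hydrogen-bond acceptors where the leaving group carries none, so the change is wider than any of the three measured swaps, and the data give no step of that kind to rest on.

The expectation is therefore a step of a number 3 percentage points lower from compound 3 to compound 4 (within the scatter), that is, none beyond the scatter, with added uncertainty downward. Compound 4 is estimated at 88% in this assay, with a range from 68% to 97%.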

Compound 4, a percentage reported as inhibition, at one concentration (the size of the read-out at that concentration, not a potency): 93%
Beside the measured number, compound 4's estimate is 5 percentage points below it; measured number inside the range.
By their numbers in this assay, from the lowest: compounds 3, 1, 4 and 2 (each within the scatter of the next).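

Working notes, continued.

Compound 4 brings the first oxygen-bearing aryl ring onto the sulfonyl sulfur, a 3,4-dimethoxyphenyl with 10 heavy atoms and 2 hydrogen-bond acceptors against the 7 heavy atoms and 0 acceptors of 4-fluorophenyl, and in this assay the read-out stays in place, with a number 2 percentage points higher from compound 3 to compound 4 (within the scatter) and a number 1 percentage points lower from compound 2 to compound 4 (within the scatter) and also a number 1 percentage points higher from compound 1 to compound 4 (within the scatter) as the steps to the three earlier compounds. For the compounds shown here, the flat picture at this position therefore now reaches beyond the halogen-bearing aryl rings of compounds 1, 2 and 3 to a larger ring carrying two methoxy groups, and no compound among the four goes against it. The data shown offer no explanation for this lack of change.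

The compounds shown leave open whether an amine or a carboxylic acid on the aryl ring, or a saturated ring such as cyclohexyl in its place, would keep the read-out at this level. All four readings come from one concentration and sit together at the high end, so any difference in potency among these aryl groups remains unresolved.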